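The compounds below may be only part of what the source reports. "The series", "measured", "known", "first", "only" and "open" are said of these compounds alone.

Two close relatives, compound 1 `COc1ccc(CNc2ncnc3c2ncn3C2CCCO2)cc1OC` and compound 2 `COc1ccc(CNc2ncnc3c2ncn3C2CCCO2)c(OC)c1`, have been tested in an ADME assay on MCF7 cells (Homo sapiens) for cytotoxicity, with a stated time of 72 h; a lower number here means a stronger inhibitor, a higher number a weaker inhibitor. Compound 1 gives > 100000 nM, which is a limit of the assay and not a number. Compound 2 gives > 100000 nM, which is also a limit and not a number. Compound 2 therefore stands at the limit of > 100000 nM in this assay, at which 2 of the 2 values shown sit.

Compound 3 `COc1cc(OC)c(OC)cc1CNc1ncnc2c1ncn2C1CCCO1` changes compound 2 in one place: methoxy in place of hydrogen on an aromatic carbon. A methoxy takes the place of a hydrogen on an aromatic carbon, ortho to one methoxy group and para to another.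

Among the compounds with values here, no measured step is available as a guide, so the expectation rests on compound 2 at > 100000 nM. No change beyond the usual scatter is expected in this assay, in either direction. The expected step is a number no higher from compound 2 to compound 3 (the limit leaves the size open). For compound 3 the estimate is 100000 nM, with an expected range of 40000 nM to 200000 nM.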

Compound 3, half-maximal inhibitory concentration: > 100000 nM
Compound 3: no number, only a limit; the forecaster's own chance of this, stated with the estimate: 80%; the middle value sits exactly at the limit.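

Compound 1, compound 2 and compound 3 each give only a limit of the assay in this assay, not a number, so the steps to compound 3 cannot be read. The compounds shown leave open whether the added methoxy changes the half-maximal inhibitory concentration at all.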